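A third group on the same nitrogen

The compounds below may be only part of what the source reports. "The series", "measured", "known", "first", "only" and "open" are said of these compounds alone.

Among the compounds with values here, in a functional assay on DU-145 cells (Homo sapiens) for inhibition, read by trypan blue exclusion, with a stated time of 72 h (on this read-out lower numbers stand for stronger inhibition and higher numbers for weaker inhibition), compound 2 `Cn1c(=O)c(S(=O)(=O)c2ccc(F)cc2F)cc2cnc(Nc3cnc4[nH]ccc4c3)nc21` gives 750 nM, the lower of the two numbers so far, while compound 1 `Cn1c(=O)c(S(=O)(=O)c2ccc(F)cc2F)cc2cnc(Nc3ccc4[nH]c(C(=O)O)cc4c3)nc21` gives 10000 nM. Compound 3 `Cn1c(=O)c(S(=O)(=O)c2ccc(F)cc2F)cc2cnc(Nc3ccc4cccc(O)c4n3)nc21` keeps the shared core and changes one place: a group of 11 heavy atoms (9 carbon, 1 nitrogen, 1 oxygen; one six-membered aromatic ring of carbon only, one six-membered aromatic ring with 1 hetero atom) in place of a group of 9 heavy atoms (7 carbon, 2 nitrogen; one five-membered aromatic ring with 1 hetero atom, one six-membered aromatic ring with 1 hetero atom), on a nitrogen on an aromatic ring. The entering group is 8-hydroxyquinolin-2-yl.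

Within the data shown here, only one measured step bears on this change, and it concerns the same place: a 13-fold lower number from compound 1 to compound 2 (1.12 log units; beyond the scatter). That large step shows that a swap here can move the number well beyond the scatter, but a single step cannot settle the direction. The group of compound 2 is smaller than that of compound 1, and compound 1 sits at 10000 nM, which leans the expectation toward a higher number. In this assay the expected step is a 2.0-fold higher number from compound 2 to compound 3 (0.30 log units; within the scatter), a moderate weakening. For compound 3 the estimated value is 1500 nM, with an expected range from 300 nM to 7000 nM.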

Compound 3, half-maximal inhibitory concentration: 5000 nM
The estimate for compound 3 lay 3.3-fold (0.52 log units) below the measured number; the range from low to high includes it.
By their numbers in this assay, from the lowest: compound 2; then compounds 3 and 1 (each within the scatter of the next).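

In this assay, the step of a 6.7-fold higher number from compound 2 to compound 3 (0.82 log units; beyond the scatter) shows that the low number of compound 2 does not carry over to every group with two aromatic rings at this nitrogen. The step of a 2.0-fold lower number from compound 1 to compound 3 (0.30 log units; within the scatter) lies within the scatter, so 8-hydroxyquinolin-2-yl and 2-carboxy-1H-indol-5-yl, though different groups, give numbers that cannot be told apart here. Nothing measured on these compounds explains the difference between compound 2 and the other two.

The three compounds cannot separate the effect of the hydroxy from that of the rest of the entering group. Also open, going by these compounds, is how 8-aminoquinolin-2-yl, with an amine in place of the hydroxy, or a group with a single ring, such as phenyl, would read at this nitrogen.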